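The source may hold more compounds than are shown below. What is called first, only, known or untested is meant among the compounds shown, and "the series" means these compounds.

Measured in a functional assay on U-251 cells (Homo sapiens) for cytotoxicity, read by resazurin assay, with stated times of 30 s and 48 h; a higher number here means a weaker inhibitor, a lower number a stronger inhibitor:
- compound 1 `CCCCc1cc2[nH]c(-c3cc(C(F)(F)F)cc(C(F)(F)F)c3)cc(=O)n2n1`, 11400 nM
- compound 2 `O=c1cc(-c2ccccc2)[nH]c2cc(-c3ccccc3)nn12`, 73600 nM

Compound 2 stands as the weaker of the two inhibitors in this assay, and its gap to compound 1 lies beyond the scatter; compound 1 gives 11400 nM. Among the compounds with values here, no step between compounds differing in one place is available, so nothing yet shows how small changes on the shared core move this assay.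

Compound 3 `Cc1ccc(-c2cc3[nH]c(-c4ccccc4)cc(=O)n3n2)cc1` differs from compound 2 by methyl in place of hydrogen on an aromatic carbon, phenyl to 4-methylphenyl. A change of one carbon, with no ring and no donors or acceptors added, gives no ground in this set for a large movement; the expected step is small, possibly a slight strengthening, and likely not beyond the scatter. The expected change is a 1.5-fold lower number from compound 2 to compound 3 (0.17 log units; within the scatter). Compound 3 is estimated at 50000 nM, with a range from 20000 nM to 150000 nM.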

Compound 3, half-maximal inhibitory concentration: 86700 nM
Compound 3: the middle estimate sits 1.7-fold (0.24 log units) below what was measured; low and high end bracket the measured number.
By their numbers in this assay, from the lowest: compound 1; then compounds 2 and 3 (each within the scatter of the next).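

Within the data shown here, the first one-place step reads in this assay as a 1.2-fold higher number from compound 2 to compound 3 (0.07 log units; within the scatter). Methyl in place of hydrogen on an aromatic carbon, para to a large group, therefore does not separate this pair, and the change from phenyl to 4-methylphenyl leaves the read-out within the scatter. No measured property is at hand that bears on this result.

Going by these compounds, whether an amine, a carboxylic acid or a longer chain such as butyl at this same position would move the number beyond the scatter remains open, as one methyl sets no trend for the position. Among these compounds, no one-place step yet links compound 1 to the other compounds, so the groups behind its value remain unassigned.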